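The compounds below may be only part of what the source reports. "The series", "measured", "known", "first", "only" and "open" are said of these compounds alone.

In an ADME assay on HFF cells (Homo sapiens) for cytotoxicity, read by MTT assay, with a stated time of 72 h (on this read-out higher numbers stand for weaker inhibition and lower numbers for stronger inhibition), compound 1, `O=C1O/C(=C\Cn2cc(-c3cc(F)cc(F)c3)nn2)C(OCc2ccccc2)=C1OCc1ccccc1`, returns only a limit, > 100000 nM. Among the measured compounds shown here, compound 2, `O=C1O[C@H]([C@@H](O)Cn2cc(C3CC3)nn2)C(OCc2ccccc2)=C1OCc1ccccc1`, gives 24300 nM in this assay, and this is the only number recorded among the two measured compounds. Compound 3, `O=C1O[C@H]([C@@H](O)Cn2cc(CCO)nn2)C(OCc2ccccc2)=C1OCc1ccccc1`, differs from compound 2 by 2-hydroxyethyl in place of cyclopropyl on an aromatic carbon. For the measured compounds named here, no measured pair shows what this change does, so the step expected for it is a 1.2-fold higher number from compound 2 to compound 3 (0.09 log units; within the scatter), which is not beyond the usual scatter of repeated measurements. Compound 3 is therefore estimated at 30000 nM in this assay, with a range from 12000 nM to 80000 nM.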

Compound 3, half-maximal inhibitory concentration: 58500 nM
Beside the measured number, compound 3's estimate is 2.0-fold (0.29 log units) below it; the measured number falls inside the stated range.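

Exchanging cyclopropyl for 2-hydroxyethyl on this aromatic carbon of the five-membered aromatic ring with 3 nitrogen gives, in this assay, a 2.4-fold higher number from compound 2 to compound 3 (0.38 log units; beyond the scatter). Among the compounds shown here, this is the first readable step at the position, and it shows that the number responds to this substituent, though only modestly. Compound 1 returns only a limit, which caps how far this read-out can follow such changes: the limit of > 100000 nM in this assay, at which 1 of the 3 values shown sits.

On these data alone, whether an amine, a carboxylic acid or a longer chain here would move the number further remains open. So does whether this step would hold on a different core.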